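The source may report more compounds than this note shows. Statements on the series, on what has been measured and on what is new or still open speak of the compounds shown alone.

Compound 1 (`CC(=O)N1N=C(c2ccc3ccccc3c2)OC1c1ccccc1Br`): 5.49 ug/mL
Compound 2 (`CC(=O)N1N=C(c2ccc3ccccc3c2)OC1c1cccc(Br)c1`): 2.34 ug/mL

In a functional assay on MCF7 cells (Homo sapiens) for antiproliferative activity, read by MTT assay, with a stated time of 48 h (a lower number here means a stronger inhibitor, a higher number a weaker inhibitor), compound 2 (2.34 ug/mL) has the lower of the two numbers. Compound 3 (`CC(=O)N1N=C(c2ccc3ccccc3c2)OC1c1cccc(F)c1`) differs from it by one swap: fluoro in place of bromo on an aromatic carbon with fluoro in place of bromo on an aromatic carbon. Going by the values given here, the only measured step (a 2.3-fold lower number from compound 1 to compound 2 (0.37 log units; beyond the scatter)) moves the bromo group and replaces nothing, so it bears only loosely on this swap, showing that a modest shift is possible. Among the compounds with values here, no measured step replaces bromo, so the expected step is small, with no direction beyond the scatter (a 1.2-fold higher number from compound 2 to compound 3 (0.08 log units; within the scatter)). Compound 3 is estimated at 2.8 ug/mL (expected range 1.1 ug/mL to 7 ug/mL).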

Compound 3, half-maximal inhibitory concentration: 1.98 ug/mL
Estimate against measurement, compound 3: 1.4-fold (0.15 log units) above; the measured number falls inside the stated range.
By their numbers in this assay, from the lowest: compounds 3 and 2 (each within the scatter of the next); then compound 1.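

In this assay, putting fluoro in place of bromo on this aromatic carbon gives a 1.2-fold lower number from compound 2 to compound 3 (0.07 log units; within the scatter), so at this position the two halogens cannot be told apart. The 3-fluorophenyl group also keeps the distance from the 2-bromophenyl group, with a 2.8-fold lower number from compound 1 to compound 3 (0.44 log units; beyond the scatter). No measurement here explains why this swap changes so little. Still open, from the compounds shown here alone, is whether an amine or a carboxylic acid in place of the fluoro would keep this level. Also open, going by these compounds, is whether fluoro in place of bromo in compound 1 would give an equally small step.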